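A Sulfonyl Group in Place of a Carbonyl Group

This account rests on a few compounds, and the source may have more. Where it says the series, first, only, none or still open, it means among the compounds named here.

Compound 1 `CCCCCCCCCCCCCCNC(=O)[C@@H](NC(=O)c1ccco1)[C@@H](C)O` gives 127000 nM in a functional assay on SiHa cells (Homo sapiens) for cytotoxicity, read by MTT assay, with a stated time of 48 h; a higher number here means a weaker inhibitor, a lower number a stronger inhibitor. Compound 2 `CCCCCCCCCCCCCCNC(=O)[C@@H](NC(=O)c1cc2ccccc2o1)[C@@H](C)O` gives 14200 nM in this assay. Compound 3 `C/C=C/C=C/C(=O)N[C@H](C(=O)NCCCCCCCCCCCCCC)[C@@H](C)O` reaches only the limit > 200000 nM in this assay. The step of an 8.9-fold lower number from compound 1 to compound 2 (0.95 log units; beyond the scatter) and the step of an at least 14-fold higher number from compound 2 to compound 3 (1.14 log units; beyond the scatter) are both beyond the scatter, whereas the step of an at least 1.5-fold higher number from compound 1 to compound 3 (0.19 log units; that floor lies within the scatter) is not. Compound 3 thus stands at the weak end of the three, at the limit (the limit of > 200000 nM in this assay, at which 1 of the 3 values shown sits). Compound 4 `CCCCCCCCCCCCCCNC(=O)[C@@H](NS(=O)(=O)c1cccs1)[C@@H](C)O` differs from compound 3 by (thiophen-2-yl)sulfonyl in place of (penta-1,3-dien-1-yl)carbonyl on an amine nitrogen. For the measured compounds named here, no measured step exchanges a carbonyl for a sulfonyl, so the expectation rests on the ring-bearing compound 1 giving 127000 nM. It rests also on compound 3 reaching only a limit of this assay. The estimated step is an at least 1.5-fold lower number from compound 3 to compound 4 (0.18 log units; that floor lies within the scatter), and compound 4 is expected to give 130000 nM, between 35000 nM and 250000 nM.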

Compound 4, half-maximal inhibitory concentration: 20400 nM
Estimate against measurement, compound 4: 6.4-fold (0.80 log units) above; measured number below the stated range.
By their numbers in this assay, from the lowest: compounds 2 and 4 (each within the scatter of the next); then compound 1. At a limit, above all of these: compound 3.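

The sulfonyl link on the amine nitrogen still gives a measurable number in this assay, with an at least 9.8-fold lower number from compound 3 to compound 4 (0.99 log units; beyond the scatter) and a 6.2-fold lower number from compound 1 to compound 4 (0.79 log units; beyond the scatter). For the compounds shown here, compound 2 and compound 4 cannot be told apart, with a 1.4-fold higher number from compound 2 to compound 4 (0.16 log units; within the scatter), so (1-benzofuran-2-yl)carbonyl is not the only group at this position that reaches such a number. Compound 3 stands at a limit, which makes the first of these steps a floor only: the limit of > 200000 nM in this assay, at which 1 of the 4 values shown sits.

Sulfonyl and ring change together in each of these steps, and the share of each stays open. Also open, going by these compounds, is how a phenyl ring on the sulfonyl, or an amine on the thiophene, would read.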